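Series notes on methyl insertion and rat microsomal stability

The source may report more compounds than this note shows. Statements on the series, on what has been measured and on what is new or still open speak of the compounds shown alone.

Compound 1 `CCc1onc(-c2ccc(Cl)cc2)c1COc1ccc(CCC(=O)O)c(C)c1C` and compound 2 `CCCc1onc(-c2ccc(Cl)cc2)c1COc1ccc(CCC(=O)O)c(C)c1C` share one core and differ only by methyl in place of hydrogen on a saturated chain carbon, two bonds along the chain from an aromatic carbon. In an ADME assay on microsomes from liver (Rattus norvegicus) for metabolic stability, with a stated time of 10 min (on this read-out higher numbers stand for a more stable compound and lower numbers for a less stable compound), compound 1 gives 45.6%, and compound 2 gives 38.4%; the step is a number 7.2 percentage points lower from compound 1 to compound 2 (within the scatter). Compound 3 `Cc1ccc(-c2noc(C(F)(F)F)c2COc2c(F)cc(CCC(=O)O)cc2F)cc1` is built on another core; the difference between the two cores is not broken down here. In this assay compound 3 gives 37.9%, a number close to those of compound 2 and compound 1. Compound 4 `Cc1ccc(-c2noc(C(F)(F)F)c2COc2c(F)cc(CC(C)C(=O)O)cc2F)cc1` is not yet measured and differs from compound 3 by methyl in place of hydrogen on a saturated chain carbon bound to a carbonyl carbon and a saturated chain carbon. This is the same kind of change as that from compound 1 to compound 2, but the place is not the same: there the methyl enters on a saturated chain carbon, two bonds along the chain from an aromatic carbon, here on a saturated chain carbon bound to a carbonyl carbon and a saturated chain carbon. Among the compounds with values here, the step from compound 3 to compound 4 is expected to be a number 2.9 percentage points lower from compound 3 to compound 4 (within the scatter), resting on the single measured instance a number 7.2 percentage points lower from compound 1 to compound 2 (within the scatter), with the different place and core as open caveats. For compound 4 the expected value in this assay is 35%, estimated between 21% and 50%.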

Compound 4, percent of the compound remaining: 54.3%
For compound 4 the middle estimate is 19.3 percentage points below the measured one; the measured number lies above the stated range.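

In this assay, methyl in place of hydrogen on a saturated chain carbon bound to a carbonyl carbon and a saturated chain carbon gives a number 16.4 percentage points higher from compound 3 to compound 4 (beyond the scatter). Set beside the earlier methyl step, a number 7.2 percentage points lower from compound 1 to compound 2 (within the scatter), this shows that the change does not carry over in this series as one fixed shift from the core of compound 1 to the core of compound 3: the same change on two cores in this assay, a number 7.2 percentage points lower (within the scatter) from compound 1 to compound 2 and a number 16.4 percentage points higher (beyond the scatter) from compound 3 to compound 4, 23.6 percentage points apart, beyond the scatter of two such steps It does not show whether the core or the place of the methyl accounts for this gap, since the two steps differ in both, and one step on each core gives no rule for either core.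

The compounds shown leave open what a methyl on a saturated chain carbon bound to a carbonyl carbon and a saturated chain carbon would give on the core of compound 1. Also open, as far as these compounds go, is how an ethyl group or a longer chain at that place on the core of compound 3 would read in this assay.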